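Cytotoxicity notes: compound 2 to compound 3

The source may report more compounds than this note shows. Statements on the series, on what has been measured and on what is new or still open speak of the compounds shown alone.

Compound 1 `O=C1OC(Cc2nc(Cc3ccccc3)no2)c2ccccc21` and compound 2 `COCCCOc1ccc(C(O)C2OC(=O)c3c(OC)cc(OC)cc32)cc1` share a core and have both been run in an ADME assay on RAW264.7 cells (Mus musculus) for cytotoxicity, read by MTT assay, with a stated time of 24 h, in the presence of a further agent that is not named here; on this read-out lower numbers stand for stronger inhibition and higher numbers for weaker inhibition. In this assay compound 1 reports only a limit, > 40000 nM. Compound 2 likewise reports only a limit, > 40000 nM. Both shown values sit at that limit (the limit of > 40000 nM in this assay, at which 2 of the 2 values shown sit), so no measured step exists within the series. As far as these compounds go, compound 3 `COc1cc(OC)c2c(c1)C(C(O)c1ccc(OCc3ccc(C#N)cc3)cc1)OC2=O` is untested and differs from compound 2 by 4-cyanophenyl in place of 2-methoxyethyl on a saturated chain carbon bound to an oxygen on an aromatic ring. Compound 3 is expected to stay at or near the limit, a step of a number no higher from compound 2 to compound 3 (the limit leaves the size open) of no size beyond the scatter. Compound 3 is estimated at 40000 nM, between 15000 nM and 80000 nM.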

Compound 3, half-maximal inhibitory concentration: > 40000 nM
Compound 3 was reported as a limit; the forecaster's own chance of this, stated with the estimate: 70%; the middle value lies on the limit itself.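

No step can be read from compound 2 to compound 3, since both report only a limit: the limit of > 40000 nM in this assay, at which 3 of the 3 values shown sit.

The compounds shown leave open whether 4-cyanophenyl in place of 2-methoxyethyl changes cytotoxicity at all, and how far any compound lies from that limit.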